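Inverting the pyrrolidine stereocentre in a melanocortin receptor ligand series

A few compounds are considered here, and "the series" means these few. Any claim that something is new, unique, unknown or untested is made for them only; others in the source may bear on it.

The measured compounds:
Compound 1, `CCC(C)C(N)c1cc(C(F)(F)F)ccc1N1CCN(C(=O)CCc2ccc(Cl)cc2Cl)CC1`, 160 nM
Compound 2, `CCN[C@H](c1cc(C(F)(F)F)ccc1N1CCN(C(=O)CCc2ccc(Cl)cc2Cl)CC1)C(C)CC`, 92 nM
Compound 3, `CCC(C)[C@H](NC[C@H]1CCCN1)c1cc(C(F)(F)F)ccc1N1CCN(C(=O)CCc2ccc(Cl)cc2Cl)CC1`, 110 nM

These three compounds share one core and differ only in what is attached to the amine nitrogen on the benzylic carbon. In an assay on HEK293 cells for displacement of a labelled ligand from Melanocortin receptor 4 (Homo sapiens) (a higher number here means a weaker inhibitor, a lower number a stronger inhibitor), compound 1 gives 160 nM. Adding an ethyl group on that nitrogen gives a 1.7-fold lower number from compound 1 to compound 2 (0.24 log units; within the scatter), and replacing the free amine by the pyrrolidinylmethylamine gives a 1.5-fold lower number from compound 1 to compound 3 (0.16 log units; within the scatter). Between the two substituted amines the step is a 1.2-fold higher number from compound 2 to compound 3 (0.08 log units; within the scatter). Compound 3 thus sits in the middle of three numbers that all lie within the scatter of one another.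

Compound 4, `CCC(C)[C@H](NC[C@@H]1CCCN1)c1cc(C(F)(F)F)ccc1N1CCN(C(=O)CCc2ccc(Cl)cc2Cl)CC1`, differs from compound 3 only in this: the two compounds have the same atoms and bonds; at least one stereo element is drawn with a configuration in one of them and without one in the other: 1 of 3 stereo elements differ; a stereocentre at a saturated ring carbon is drawn R in compound 3 and S in compound 4. Among the compounds with values here, none of the measured steps changes a stereocentre, so no direct precedent exists; the nearest evidence is that changes at this amine, including the step from compound 2 to compound 3, stayed within the scatter. An expected step of no change at the digits printed from compound 3 to compound 4 (within the scatter) therefore follows, with no change beyond the scatter anticipated. Compound 4 is estimated at 110 nM, with a range from 45 nM to 270 nM.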

Compound 4, inhibition constant: 64 nM
For compound 4 the middle estimate is 1.7-fold (0.24 log units) above the measured one; low and high end bracket the measured number.
By their numbers in this assay, from the lowest: compounds 4, 2, 3 and 1 (each within the scatter of the next, the first and the last beyond it).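

In this assay, within the data shown here, inverting the stereocentre on the pyrrolidine ring gives a 1.7-fold lower number from compound 3 to compound 4 (0.24 log units; within the scatter) and so shows no clear preference for either drawn configuration at this ring carbon, something no earlier step could test. Among these compounds, the same compound stays within the scatter of the ethylamine, with a 1.4-fold lower number from compound 2 to compound 4 (0.16 log units; within the scatter) as the step, but a 2.5-fold lower number from compound 1 to compound 4 (0.40 log units; beyond the scatter) is, though modest, the only step here beyond the scatter from the free amine, which neither compound 2 nor compound 3 reached. The stereochemical reading carries one reservation: the fact that one of compounds 3 and 4 is drawn with a defined configuration and the other without, at the place where they differ.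

The compounds shown leave open whether this tolerance extends to a piperidin-2-yl group in place of the pyrrolidin-2-yl, or to a methyl group on the pyrrolidine nitrogen. They also leave open how a longer chain in place of the ethyl group would behave.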